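This account rests on a few compounds, and the source may have more. Where it says the series, first, only, none or still open, it means among the compounds named here.

Working notes on the series. Compound 1 `CC1=C(C(=O)OC(C)(C)C)C(c2ccsc2)NC(=O)N1`, compound 2 `CC1=C(C(=O)C2CC2)C(c2ccsc2)NC(=O)N1` and compound 3 `CCC(C)OC(=O)C1=C(C)NC(=O)NC1c1ccsc1` share one core. In an assay on membranes from HEK293 cells for displacement of a labelled ligand from adenosine receptor A2b (Homo sapiens), read by scintillation counting, with a stated time of 30 min, tested at 1 uM (on this read-out higher numbers stand for more inhibition at the one concentration tested (going by the name of the read-out) and lower numbers for less inhibition), compound 1 gives 47%, compound 2 gives 1% and compound 3 gives 39%, the second highest of the three numbers. The gap a number 8 percentage points lower from compound 1 to compound 3 (within the scatter) is within the scatter, whereas a number 46 percentage points lower from compound 1 to compound 2 (beyond the scatter) and a number 38 percentage points higher from compound 2 to compound 3 (beyond the scatter) are large and both involve cyclopropyl on the carbonyl carbon, a different place from the oxygen varied here.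

Compound 4 `CC1=C(C(=O)OC2CCCCC2)C(c2ccsc2)NC(=O)N1` differs from compound 3 by cyclohexyl in place of sec-butyl on an oxygen next to a carbonyl group. Among the measured compounds shown here, only the step from compound 1 to compound 3 concerns the same oxygen, and it stayed within the scatter, so no step beyond the scatter is expected in this assay. Compound 4 is therefore expected near 40%, between 20% and 60%, an expected step of a number 1 percentage points higher from compound 3 to compound 4 (within the scatter).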

Compound 4, a percentage reported as inhibition, at one concentration (the size of the read-out at that concentration, not a potency): 4%
Compound 4: the middle estimate sits 36 percentage points above what was measured; the measured number lies below the stated range.
By their numbers in this assay, from the lowest: compounds 2 and 4 (each within the scatter of the next); then compounds 3 and 1 (each within the scatter of the next).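

In this assay the group on the oxygen next to a carbonyl group does matter, a reading that sec-butyl and tert-butyl alone did not give: with cyclohexyl there is a number 35 percentage points lower from compound 3 to compound 4 (beyond the scatter) and also a number 43 percentage points lower from compound 1 to compound 4 (beyond the scatter) as a large step. Keeping the ester does not by itself keep the read-out, as there is only a number 3 percentage points higher from compound 2 to compound 4 (within the scatter) when cyclohexyloxy replaces cyclopropyl on the carbonyl carbon. Nothing available explains the loss seen with cyclohexyl.

Open, as far as these compounds go, is whether cyclopentyl or an unbranched pentyl chain on that oxygen reads like sec-butyl or like cyclohexyl.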